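Aryl exchange from compound 2 to compound 3

The source may report more compounds than this note shows. Statements on the series, on what has been measured and on what is new or still open speak of the compounds shown alone.

In a functional assay on KB cells (Homo sapiens) for antiproliferative activity, read by sulforhodamine B assay, with a stated time of 3 days (a higher number here means that more compound is needed for the effect, a lower number that less compound is needed), compound 1 `CCC1=C(O)c2c(oc(-c3ccc(OC)cc3)cc2=O)C(CC)(CC)C1=O` gives 17.7 uM and compound 2 `CCC1=C(O)c2c(oc(-c3ccc(OC)c(F)c3)cc2=O)C(CC)(CC)C1=O` gives 26.7 uM so compound 2 stands level with compound 1 within the scatter. Compound 3 `CCC1=C(O)c2c(oc(-c3cc(C)ccc3C)cc2=O)C(CC)(CC)C1=O` carries 2,5-dimethylphenyl in place of 3-fluoro-4-methoxyphenyl on an aromatic carbon on the shared core. Within the data shown here, the only measured step, a 1.5-fold higher number from compound 1 to compound 2 (0.18 log units; within the scatter) for fluoro in place of hydrogen on an aromatic carbon, stays within the scatter. Among the measured compounds shown here, no measured step covers an exchange of this size, so no direction is firmly supported. The expected step is a 1.3-fold lower number from compound 2 to compound 3 (0.13 log units; within the scatter) and none beyond the scatter is expected. The estimate for compound 3 is 20 uM within an expected range of 8 uM to 50 uM overall.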

Compound 3, concentration for half-maximal effect: 14.5 uM
Estimate against measurement, compound 3: 1.4-fold (0.14 log units) above; the measured number falls inside the stated range.
By their numbers in this assay, from the lowest: compounds 3, 1 and 2 (each within the scatter of the next).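

In this assay the aryl group next to the ring oxygen takes a whole-ring exchange without a clear shift: a 1.8-fold lower number from compound 2 to compound 3 (0.27 log units; within the scatter) and a 1.2-fold lower number from compound 1 to compound 3 (0.09 log units; within the scatter) both stay within the scatter. The methoxy group is therefore not needed to hold this level of activity, since 2,5-dimethylphenyl, made of carbon only, stands level with both oxygen-bearing aryl groups. No supporting data bear on this result. Still open, going by these compounds, is whether an amine or a carboxylic acid on this aryl ring would move the number beyond the scatter.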